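The source may hold more compounds than are shown below. What is called first, only, known or untested is meant among the compounds shown, and "the series" means these compounds.

Compound 3 `CCOC(=O)c1c(-c2ccc(Cl)cc2)cc(-c2ccccc2)nc1Nc1ccc(OC)cc1` gives 68.8% in a functional assay on the whole organism (strain Wister albino) for inhibition, with Rattus norvegicus as the target, read by paw edema, with stated times of 1 h and 3 h, at a dose of 50 mg/kg by the intraperitoneal route; on this read-out lower numbers stand for less inhibition and higher numbers for more inhibition at the one dose given (going by the name of the read-out). Among the three measured compounds it stands second highest: compound 1 `CCOC(=O)c1c(-c2ccc(Cl)cc2)cc(-c2ccccc2)nc1N1CCN(C)CC1` gives 67.8%, and the two lie within the scatter of each other, while compound 2 `CCOC(=O)c1c(-c2ccc(Cl)cc2)cc(-c2ccccc2)nc1Nc1ccc(C)cc1` gives 82.4%, so that a number 13.6 percentage points lower from compound 2 to compound 3 (beyond the scatter). Compound 4 `CCOC(=O)c1c(-c2ccc(Cl)cc2)cc(-c2ccccc2)nc1Nc1ccc(Cl)cc1` differs from compound 3 in one place: chloro in place of methoxy on an aromatic carbon. Among the measured compounds shown here, the one measured step that bears on this place is the exchange of methyl for methoxy, which gave a number 13.6 percentage points lower from compound 2 to compound 3 (beyond the scatter); the steps of a number 14.6 percentage points higher from compound 1 to compound 2 (beyond the scatter) and a number 1 percentage points higher from compound 1 to compound 3 (within the scatter) concern a different part of the shared core. For the measured compounds named here, no measured compound carries chloro at this place, so the direction of the new change has no direct precedent. Compound 4 is expected to land between the two, because a number 13.6 percentage points lower from compound 2 to compound 3 (beyond the scatter) shows that the group at this place shifts the read-out by a modest amount. The expected step is a number 7.2 percentage points higher from compound 3 to compound 4 (within the scatter). Compound 4 is therefore estimated to give 76%, with a range from 62% to 88%.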

Compound 4, a percentage reported as inhibition, in the whole organism at one dose (the size of the read-out at that dose, not a potency): 31.2%
For compound 4 the middle estimate is 44.8 percentage points above the measured one; measured number below the stated range.
By their numbers in this assay, from the lowest: compound 4; then compounds 1 and 3 (each within the scatter of the next); then compound 2.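

In this assay, the group on this aromatic carbon, para to a large group, can move the read-out much further than the exchange of methyl for methoxy had shown: chloro in place of methoxy gives a number 37.6 percentage points lower from compound 3 to compound 4 (beyond the scatter) and chloro in place of methyl gives a number 51.2 percentage points lower from compound 2 to compound 4 (beyond the scatter) in the same series. Chloro therefore does not fall within the span set by methyl and methoxy but lies beyond the scatter under both, and the (4-chlorophenyl)amino group also stands under 4-methylpiperazin-1-yl, with a number 36.6 percentage points lower from compound 1 to compound 4 (beyond the scatter) for that exchange. No measurement shown here accounts for this drop.

Going by these compounds, whether fluoro, bromo, hydroxy or a carboxylic acid at this place would read like chloro or like methyl remains open. So does whether the same order would hold at other doses.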